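The compounds below may be only part of what the source reports. "The series", "measured", "known", "first", "only" and "open" are said of these compounds alone.

Three compounds have been measured in a toxicity assay on MDCK cells (Canis lupus familiaris) for cytotoxicity, read by crystal violet staining, with a stated time of 48 h; a lower number here means that less compound is tolerated, a higher number that more compound is tolerated:

- compound 1 `Cc1ccc2[nH]c(=O)c(CN(CCCO)Cc3ccc(C(C)(C)C)cc3)cc2c1`, which gives only a limit there, > 10000 nM
- compound 2 `Cc1ccc2[nH]c(=O)c(CN(Cc3ccc(OCC(=O)OC(C)(C)C)cc3)Cc3ccc(C(C)(C)C)cc3)cc2c1`, which likewise gives only a limit, > 10000 nM
- compound 3 `Cc1ccc2[nH]c(=O)c(CN(Cc3ccc(OCC(=O)O)cc3)Cc3ccc(C(C)(C)C)cc3)cc2c1`, which also gives only a limit, > 10000 nM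

Compound 3 therefore stands at the limit itself, and so do the two others: the limit of > 10000 nM in this assay, at which 3 of the 3 values shown sit. The two steps that lead to compound 3 are accordingly not readable; that a step that the two limits leave unreadable from compound 1 to compound 3 and that a step that the two limits leave unreadable from compound 2 to compound 3 both remain of unknown size. Compound 4 `COc1ccc(CN(Cc2ccc(C(C)(C)C)cc2)Cc2cc3cc(C)ccc3[nH]c2=O)cc1` is the next member of the series; it differs from compound 3 by hydrogen in place of carboxy on a saturated chain carbon bound to an oxygen on an aromatic ring. Among the compounds with values here, no measured step bears readably on this change, since every value shown sits at the same limit (the limit of > 10000 nM in this assay, at which 3 of the 3 values shown sit). For compound 4 no step beyond the scatter can thus be derived in this assay , and the expected outcome is once more a limit rather than a number. On that basis compound 4 is estimated at 15000 nM, with a range from 7000 nM to 40000 nM. The step this estimate implies, a step that the limit leaves unreadable from compound 3 to compound 4, is expected to be none beyond the scatter.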

Compound 4, half-maximal cytotoxic concentration: > 10000 nM
Compound 4: a limit, no number; the forecaster's own chance of this, stated with the estimate: 85%; the middle value is on the limit's open side.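

In this assay compound 4 gives > 10000 nM, which is a limit and not a number. The steps to compound 4 from compound 1, compound 2 and compound 3 therefore cannot be read: the limit of > 10000 nM in this assay, at which 4 of the 4 values shown sit.

The compounds shown leave open how much compound is tolerated in this assay by any of them, and whether any of these changes alters it.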